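Replacing the amino linker with a direct aryl bond

The source may hold more compounds than are shown below. What is called first, only, known or untested is meant among the compounds shown, and "the series" means these compounds.

Three compounds sharing one core were tested in an in vitro functional assay on B300-19 cells for antagonist activity at C-C chemokine receptor type 4 (Homo sapiens), read by GTPgammaS binding; a lower number here means a stronger inhibitor, a higher number a weaker inhibitor. Compound 1 `COc1cc2nc(N3CCC(N4CCCC(CO)C4)CC3)nc(NCc3ccc(Cl)cc3)c2cc1OC` gives 87 nM. Compound 2 `COc1cc2nc(N3CCC(N4CCCC(CO)C4)CC3)nc(NCCCc3ccc(Cl)cc3)c2cc1OC` gives 180 nM, the highest number of the three. Compound 3 `COCC1CCCN(C2CCN(c3nc(Nc4ccc(Cl)cc4)c4cc(OC)c(OC)cc4n3)CC2)C1` gives 52 nM. The step of a 2.1-fold higher number from compound 1 to compound 2 (0.32 log units; beyond the scatter) shows that lengthening the chain raised the number modestly. Compound 4 `COc1cc2nc(N3CCC(N4CCCC(CO)C4)CC3)nc(-c3ccc(Cl)cc3)c2cc1OC` differs from compound 2 by 4-chlorophenyl in place of (3-(4-chlorophenyl)propyl)amino on an aromatic carbon. Among the measured compounds shown here, no measured step removes the nitrogen and the chain altogether, so only the step in which the chain was lengthened bears on it, and it points toward a lower number when the chain is shorter. Compound 4 is therefore expected to show a modest step of a 1.5-fold lower number from compound 2 to compound 4 (0.18 log units; within the scatter), toward a lower number, with wide uncertainty. The estimate for compound 4 is 120 nM, within a range from 25 nM to 600 nM.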

Compound 4, half-maximal inhibitory concentration: > 1000 nM
Compound 4 was reported as a limit; the forecaster's own chance of this, stated with the estimate: 5%; middle value at least 8.3-fold (0.92 log units) from the limit.
By their numbers in this assay, from the lowest: compounds 3 and 1 (each within the scatter of the next); then compound 2. At a limit, above all of these: compound 4.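

In this assay, compound 4 is known only as a limit: the limit of > 1000 nM in this assay, at which 1 of the 4 values shown sits. Attaching the 4-chlorophenyl directly to this aromatic carbon gives an at least 5.5-fold higher number from compound 2 to compound 4 (0.74 log units; beyond the scatter) and an at least 11-fold higher number from compound 1 to compound 4 (1.06 log units; beyond the scatter), a larger change than the one seen when the chain was lengthened. At this position, then, changing the chain length is tolerated far better than removing the linking amino nitrogen along with the chain.

Whether the nitrogen itself or merely the spacing of the aromatic ring accounts for the loss remains open. An ether oxygen or a methylene linker in its place would help separate the two.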